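Chain lengthening on the ester tail in the series

A few compounds are considered here, and "the series" means these few. Any claim that something is new, unique, unknown or untested is made for them only; others in the source may bear on it.

Compound 2 `CCCCCCCCCCOC(=O)CCC(=O)N1CCN(CCCOc2cc3c(Nc4ccc(F)c(Cl)c4)ncnc3cc2OC)CC1` gives 2% in a functional assay on A549 cells (Homo sapiens) for cytotoxicity, read by MTT assay, with a stated time of 24 h, tested at 80 uM (a higher number here means a weaker effect of the compound at the concentration tested, a lower number a stronger effect), the lowest of the two numbers available; compound 1 `CCCCCCCOC(=O)CCC(=O)N1CCN(CCCOc2cc3c(Nc4ccc(F)c(Cl)c4)ncnc3cc2OC)CC1` gives 27.2%. For the measured compounds named here, the one step in hand, a number 25.2 percentage points lower from compound 1 to compound 2 (beyond the scatter), shows the longer ester chain with the stronger effect. Compound 3 `CCCCCCCCCCCCCCCOC(=O)CCC(=O)N1CCN(CCCOc2cc3c(Nc4ccc(F)c(Cl)c4)ncnc3cc2OC)CC1` extends the chain again: pentyl in place of hydrogen on a saturated chain carbon, ten or more bonds along the chain from an oxygen next to a carbonyl group. With compound 2 already near the floor of the read-out, the expected step of a number 1 percentage points higher from compound 2 to compound 3 (within the scatter) is none beyond the scatter. For compound 3 the estimate is therefore 3%, within the range 0% to 15%.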

Compound 3, a percentage reported as activity, at one concentration (the size of the read-out at that concentration, not a potency): 81.1%
Estimate against measurement, compound 3: 78.1 percentage points below; the measured number lies above the stated range.
By their numbers in this assay, from the lowest: compound 2; then compound 1; then compound 3.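

Along the ester tail, lengthening does not act in one direction in this assay: a number 79.1 percentage points higher from compound 2 to compound 3 (beyond the scatter) undoes the earlier gain, and a number 53.9 percentage points higher from compound 1 to compound 3 (beyond the scatter) leaves the longest chain with a weaker effect than the shortest. The pattern of a longer chain giving a lower number therefore holds only for the first step, and compound 3 goes against it. Nothing at hand bears on why the number turns upward.

Where the turn falls among chains of intermediate length stays open. So does whether a branched chain, or a chain ending in an amine or a carboxylic acid, would hold the low number of compound 2.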